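Vinyl for phenyl on a sugar-like ring: two stereoisomers

This account rests on a few compounds, and the source may have more. Where it says the series, first, only, none or still open, it means among the compounds named here.

Of the compounds shown here, three have been tested in a functional assay on HL-60 cells (Homo sapiens) for antiproliferative activity, read by MTT assay; on this read-out higher numbers stand for weaker inhibition and lower numbers for stronger inhibition. Compound 1 `C=C[C@@H]1O[C@H](COCc2ccccc2)[C@@H](OCc2ccccc2)[C@H](OCc2ccccc2)[C@H]1O` gives 11800 nM. Compound 3 `O[C@@H]1[C@@H](OCc2ccccc2)[C@H](OCc2ccccc2)[C@@H](COCc2ccccc2)O[C@H]1c1ccccc1` gives 26300 nM. Compound 2 `O[C@@H]1[C@@H](OCc2ccccc2)[C@H](OCc2ccccc2)[C@@H](COCc2ccccc2)O[C@@H]1c1ccccc1` is reported only as "not active" (no number reported), with no number. The two cores differ as follows: the two compounds have the same atoms and bonds and differ only in configuration as drawn: 1 of 5 stereo elements differ; a stereocentre at a saturated ring carbon is drawn S in compound 3 and R in compound 2. The change vinyl in place of phenyl on a saturated ring carbon gave a 2.2-fold lower number from compound 3 to compound 1 (0.35 log units; beyond the scatter). Compound 4 `C=C[C@H]1O[C@H](COCc2ccccc2)[C@@H](OCc2ccccc2)[C@H](OCc2ccccc2)[C@H]1O` carries the same change on the core of compound 2, (vinyl in place of phenyl on a saturated ring carbon), and the surroundings of the changed carbon read the same in both cases. Since compound 2 gave no number in this assay and the earlier step was modest, compound 4 is expected to remain weak, and its value is estimated at 40000 nM, likely between 15000 nM and 120000 nM, with a real chance that again only a limit is reported.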

Compound 4, half-maximal inhibitory concentration: "not active" (no number reported)
Compound 4 has no reported number here; the estimate stays without a comparison.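

Going by these compounds alone, compound 2 and compound 4 are both reported only as "not active", so no step between them can be read. From the compounds shown here alone, whether vinyl in place of phenyl changes activity on this core remains open.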